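Moving the methyl: compound 1 to compound 4

The compounds below may be only part of what the source reports. "The series", "measured", "known", "first", "only" and "open" are said of these compounds alone.

Measured so far in an ADME assay on microsomes (Rattus norvegicus) for metabolic stability; a lower number here means that the compound disappears faster, a higher number that the compound lasts longer
- compound 1 (`Cc1coc(Cn2nc3ccc(-c4ccc(OC(F)(F)F)cc4)cn3c2=O)n1`) gives 0.683 h
- compound 2 (`Cc1noc(Cn2nc3ccc(-c4ccc(Oc5ccc(F)cc5)cc4)cn3c2=O)n1`) gives 1.42 h
- compound 3 (`O=c1n(Cc2noc(CO)n2)nc2ccc(-c3ccc(Oc4ccc(F)cc4)cc3)cn12`) gives 0.533 h

Compound 1 lies within the usual scatter of compound 3, and compound 2 stands higher, with a gap just beyond the scatter. The next structure is compound 4 (`Cc1cnc(Cn2nc3ccc(-c4ccc(OC(F)(F)F)cc4)cn3c2=O)o1`), which holds the same atoms as compound 1, joined differently: 5-methyl-1,3-oxazol-2-yl in place of 4-methyl-1,3-oxazol-2-yl on a saturated chain carbon bound to an aromatic nitrogen. It carries 5-methyl-1,3-oxazol-2-yl in place of 4-methyl-1,3-oxazol-2-yl on a saturated chain carbon bound to an aromatic nitrogen.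

Among the compounds with values here, one measured step touches this place, a 2.7-fold lower number from compound 2 to compound 3 (0.43 log units; beyond the scatter), and it is modest. That step exchanges one ring and substituent for another, so it bears only loosely here. Within the data shown here, no measured pair isolates a shift of the methyl alone. No change beyond the scatter is therefore expected in this assay, and the value of compound 1 at 0.683 h serves as the anchor. The expected move is a 1.1-fold lower number from compound 1 to compound 4 (0.04 log units; within the scatter), which stays within the scatter. For compound 4 the estimate is 0.62 h, with an expected range of 0.3 h to 1.2 h.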

Compound 4, half-life: 0.4 h
For compound 4 the middle estimate is 1.6-fold (0.19 log units) above the measured one; measured number inside the range.
By their numbers in this assay, from the lowest: compounds 4, 3 and 1 (each within the scatter of the next); then compound 2.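

Within the data shown here, this is the first pair in which only the site of the methyl differs, with 5-methyl-1,3-oxazol-2-yl in place of 4-methyl-1,3-oxazol-2-yl on a saturated chain carbon bound to an aromatic nitrogen; in this assay it gives a 1.7-fold lower number from compound 1 to compound 4 (0.23 log units; within the scatter). On this single pair, with the rest of the structure unchanged, the two methyl-oxazole isomers are not told apart by this read-out. No measurement at hand speaks to the origin of this result.

Still open is how the 1,3-oxazol-2-yl and 1,2,4-oxadiazole groups compare on an otherwise identical structure, as no pair shown isolates that exchange. Also open, on these data alone, is how a primary amine or a carboxylic acid in place of the methyl on either 1,3-oxazol-2-yl group would read in this assay.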